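Quinazoline series: pyridinylmethoxy in place of cyclopentylmethyl

This account rests on a few compounds, and the source may have more. Where it says the series, first, only, none or still open, it means among the compounds named here.

Measured so far in an ADME assay on HEK293 cells for agonist activity at Toll-like receptor 8 (Homo sapiens), read by a luciferase reporter, with a stated time of 6 h; on this read-out lower numbers stand for an effect already at smaller amounts and higher numbers for an effect only at larger amounts of compound:
- compound 1 `CCCCCNc1nc(N)nc2ccccc12`: 0.1 uM
- compound 2 `CCCCNc1nc(N)nc2ccc(CCc3ccc(N(C)C)cc3)cc12`: 0.5 uM
- compound 3 `CCCCNc1nc(N)nc2cccc(CC3CCCC3)c12`: > 25 uM

Compound 1 and compound 2 both give numbers in this assay, and the value of compound 1 is lower than that of compound 2. Compound 3 is different: its result in this assay is only a limit, (the limit of > 25 uM in this assay, at which 1 of the 3 values shown sits), so no number is known for it. On the values shown, compound 3 therefore stands at the weak end, with an effect not seen within the range tested, while compound 1 and compound 2 sit at the other end.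

Compound 4 `CCCCNc1nc(N)nc2cccc(OCc3ccccn3)c12` is the next one to be run in this assay. It differs from compound 3 in one place: (pyridin-2-yl)methoxy in place of cyclopentylmethyl on an aromatic carbon. Among the measured compounds shown here, no step between two measured compounds covers this change, so the direction has to be guessed from the change itself and from where compound 3 stands. Since compound 3 sits at a limit, any effect seen for compound 4 within range would count as a move to smaller amounts; a move the other way cannot be seen. The expectation is a step of moderate size from the limit toward smaller amounts, an at least 3.1-fold lower number from compound 3 to compound 4 (0.49 log units; beyond the scatter), with wide uncertainty. Compound 4 is estimated at 8 uM, with a range from 1 uM to 25 uM.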

Compound 4, minimum effective concentration: 18.5 uM
Compound 4: the middle estimate sits 2.3-fold (0.36 log units) below what was measured; low and high end bracket the measured number.
By their numbers in this assay, from the lowest: compound 1; then compound 2; then compound 4. At a limit, above all of these: compound 3.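

In this assay, among the compounds shown here, compound 4 gives the first actual number for a group on this aromatic carbon, 18.5 uM, carrying (pyridin-2-yl)methoxy in place of cyclopentylmethyl, so a substituent at this place does not rule out an effect within the tested range. The change amounts to an at least 1.3-fold lower number from compound 3 to compound 4 (0.13 log units; that floor lies within the scatter), and on that floor alone the gain is not separated from the usual scatter of repeated measurements. The true size of the step cannot be read, because compound 3 stands at a limit and has no number: the limit of > 25 uM in this assay, at which 1 of the 4 values shown sits.

The oxygen link and the (pyridin-2-yl) ring enter together, so the compounds shown do not tell which of the two goes with the measurable effect; a benzyloxy group or a cyclopentylmethoxy group on the same aromatic carbon would separate them. For the compounds shown here, also open is how far the value at this place can move with a smaller group such as methoxy, or with an aminomethyl group, as the two compounds here give only one number and one limit.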